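Swapping bromo for fluoro at an assay limit

The source may report more compounds than this note shows. Statements on the series, on what has been measured and on what is new or still open speak of the compounds shown alone.

In a functional assay on MDA-MB-231 cells (Homo sapiens) for antiproliferative activity, read by MTT assay, with a stated time of 48 h (on this read-out higher numbers stand for weaker inhibition and lower numbers for stronger inhibition), compound 1 (`C/C(=C\CC/C(C)=C/CC[C@@H]1[C@@]2(C)CCC(=O)C(C)(C)[C@H]2CC[C@@]1(C)O)CC/C=C(\C)C(=O)OCc1cn(-c2ccccc2Br)nn1`) gives > 150000 nM as a limit of the assay, not a number. Compound 2 (`C/C(=C\CC/C(C)=C/CC[C@@H]1[C@@]2(C)CCC(=O)C(C)(C)[C@H]2CC[C@@]1(C)O)CC/C=C(\C)C(=O)OCc1cn(C[C@@H]2O[C@H](n3ccc(=O)[nH]c3=O)[C@H]3OC(C)(C)O[C@H]32)nn1`) gives > 150000 nM as a limit too. Compound 1 therefore stands at the limit of > 150000 nM in this assay, at which 2 of the 2 values shown sit, and has no true number yet. Compound 3 (`C/C(=C\CC/C(C)=C/CC[C@@H]1[C@@]2(C)CCC(=O)C(C)(C)[C@H]2CC[C@@]1(C)O)CC/C=C(\C)C(=O)OCc1cn(-c2ccccc2F)nn1`) has fluoro in place of bromo on an aromatic carbon, ortho to a large group. For the measured compounds named here, no measured step guides this swap, so no change beyond the usual scatter is expected, an estimated a number no higher from compound 1 to compound 3 (the limit leaves the size open) in size. Compound 3 is estimated at 150000 nM within a range from 60000 nM to 300000 nM and may well give only a limit.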

Compound 3, half-maximal inhibitory concentration: > 150000 nM
Compound 3: only a limit was reported; the forecaster's own chance of this, stated with the estimate: 75%; the middle value lies on the limit itself.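

No step can be read from compound 1 to compound 3, because each gives only a limit of the assay, not a number: the limit of > 150000 nM in this assay, at which 3 of the 3 values shown sit. The compounds shown leave open what true value any of them has in this assay, and whether fluoro in place of bromo changes it.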